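This account rests on a few compounds, and the source may have more. Where it says the series, first, only, none or still open, it means among the compounds named here.

Compound 1 `COc1cc2c(Oc3ccc(NC(=O)c4nn(-c5ccccc5)c(=O)c5ccccc45)cc3F)ccnc2cc1OCCCN1CCCC1` gives 1130 nM in a functional assay on MDA-MB-231 cells (Homo sapiens) for cytotoxicity, read by MTT assay, with a stated time of 72 h; on this read-out higher numbers stand for weaker inhibition and lower numbers for stronger inhibition. Compound 2 `COc1cc2c(Oc3ccc(NC(=O)c4nn(-c5ccc(Br)cc5)c(=O)c5ccccc45)cc3F)ccnc2cc1OCCCN1CCCC1` gives 1160 nM in this assay; the step of a 1.0-fold higher number from compound 1 to compound 2 (0.01 log units; within the scatter) leaves the number within the scatter, so compound 2 stands alongside compound 1 with no separation between the two. Compound 3 `COc1ccc(-n2nc(C(=O)Nc3ccc(Oc4ccnc5cc(OCCCN6CCCC6)c(OC)cc45)c(F)c3)c3ccccc3c2=O)cc1` differs from compound 2 by methoxy in place of bromo on an aromatic carbon. Within the data shown here, only that single step bears on this change, and it was flat. A step of the same kind is expected, a 1.0-fold higher number from compound 2 to compound 3 (0.01 log units; within the scatter), with no shift beyond the scatter in either direction. Compound 3 is therefore estimated at 1200 nM, with a range from 500 nM to 2900 nM.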

Compound 3, half-maximal inhibitory concentration: 3450 nM
The estimate for compound 3 lay 2.9-fold (0.46 log units) below the measured number, and the stated range ends below it.
By their numbers in this assay, from the lowest: compounds 1 and 2 (each within the scatter of the next); then compound 3.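

In this assay this position on the aromatic ring is not indifferent to what it carries: the change from bromo to methoxy gives a 3.0-fold higher number from compound 2 to compound 3 (0.47 log units; beyond the scatter), and the change from hydrogen to methoxy gives a 3.1-fold higher number from compound 1 to compound 3 (0.48 log units; beyond the scatter). The flat step from hydrogen to bromo therefore does not hold for every group placed here, and methoxy is the one group shown that separates from the others. No measurement at hand accounts for this difference between methoxy and bromo.

On these data alone, whether the higher number is particular to methoxy remains open. An ethoxy, a hydroxyl, an amine or a chloro group at this place could show how far it extends.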